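From 2,4-dimethoxyphenyl to 2,5-dimethoxyphenyl in compound 4

The source may report more compounds than this note shows. Statements on the series, on what has been measured and on what is new or still open speak of the compounds shown alone.

In a functional assay on A549 cells (Homo sapiens) for antiproliferative activity, read by MTT assay, with a stated time of 72 h (a lower number here means a stronger inhibitor, a higher number a weaker inhibitor), compound 1 (`COc1cc(C(=O)c2sc3ccccc3c2-c2ccccc2)cc(OC)c1OC`) gives 5000 nM, compound 2 (`COc1cc(C(=O)c2sc3ccccc3c2-c2ccc(C)cc2)cc(OC)c1OC`) gives 7800 nM and compound 3 (`COc1ccc(-c2c(C(=O)c3cc(OC)c(OC)c(OC)c3)sc3ccccc23)c(OC)c1`) gives 5800 nM. Compound 3 is not separated from either of the others, with steps of a 1.2-fold higher number from compound 1 to compound 3 (0.06 log units; within the scatter) and a 1.3-fold lower number from compound 2 to compound 3 (0.13 log units; within the scatter).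

Compound 4 (`COc1ccc(OC)c(-c2c(C(=O)c3cc(OC)c(OC)c(OC)c3)sc3ccccc23)c1`) has the same atoms as compound 3, joined differently, with 2,5-dimethoxyphenyl in place of 2,4-dimethoxyphenyl on an aromatic carbon. Among the measured compounds shown here, no measured step exchanges one dimethoxyphenyl pattern for another, so the evidence is indirect. The closest steps at this place are a 1.2-fold higher number from compound 1 to compound 3 (0.06 log units; within the scatter), which introduces 2,4-dimethoxyphenyl, and a 1.6-fold higher number from compound 1 to compound 2 (0.19 log units; within the scatter), which adds methyl. Neither exceeds the scatter, so no change beyond the scatter is expected here.

The expected step is a 1.1-fold lower number from compound 3 to compound 4 (0.02 log units; within the scatter). The estimated value for compound 4 is 5500 nM, with an expected range from 2500 nM to 12000 nM.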

Compound 4, half-maximal inhibitory concentration: > 10000 nM
Compound 4: only a limit was reported; the forecaster's own chance of this, stated with the estimate: 5%; middle value at least 1.8-fold (0.25 log units) away from the limit.
By their numbers in this assay, from the lowest: compounds 1, 3 and 2 (each within the scatter of the next). At a limit, above all of these: compound 4.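

In this assay compound 4 is the only compound here without a number, having only a limit: the limit of > 10000 nM in this assay, at which 1 of the 4 values shown sits.

The steps are floors, an at least 1.7-fold higher number from compound 3 to compound 4 (0.23 log units; that floor lies within the scatter), an at least 1.2-fold higher number from compound 2 to compound 4 (0.10 log units; that floor lies within the scatter) and an at least 2.0-fold higher number from compound 1 to compound 4 (0.30 log units; that floor lies within the scatter), so none of them shows that the change separates compound 4 from the others. Even so, phenyl, 4-methylphenyl and 2,4-dimethoxyphenyl all gave numbers at this place, whereas 2,5-dimethoxyphenyl, made of the same atoms as 2,4-dimethoxyphenyl but joined differently, gave only a limit.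

From the compounds shown here alone, how far the true value of compound 4 lies beyond that limit stays open, and with it the real size of the change. Also open is whether a phenyl ring carrying a hydroxyl or an amine at this place would give a lower number than the compounds shown.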